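The compounds below may be only part of what the source reports. "The series", "measured", "known", "first", "only" and "open" are said of these compounds alone.

Measured compounds in a functional assay on HepG2 cells (Homo sapiens) for antiproliferative activity, read by MTT assay, with a stated time of 48 h; on this read-out higher numbers stand for weaker inhibition and lower numbers for stronger inhibition:

compound 1 `COc1cc2oc(-c3ccccc3)cc(=O)c2c(O)c1OCCCN1CCCCC1` — 22300 nM
compound 2 `CCN(CC)CCCCOc1c(OC)cc2oc(-c3ccccc3)cc(=O)c2c1O` — 7100 nM
compound 3 `CCN(CC)CCCOc1c(OC)cc2oc(-c3ccccc3)cc(=O)c2c1O` — 3700 nM

Compound 2 stands second highest of the three numbers in this assay: compound 3 lies nearer, and the gap between them, a 1.9-fold lower number from compound 2 to compound 3 (0.28 log units; within the scatter), is within the scatter; compound 1 lies further off, at a 3.1-fold lower number from compound 1 to compound 2 (0.50 log units; beyond the scatter). The other measured step, a 6.0-fold lower number from compound 1 to compound 3 (0.78 log units; beyond the scatter), is the widest of the three. All three measured steps concern the amine at the far end of the chain, not the ether on the core.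

Compound 4 `CCN(CC)CCCCOc1c(OCc2ccccc2)cc2oc(-c3ccccc3)cc(=O)c2c1O` is not yet measured. It differs from compound 2 by phenyl in place of hydrogen on a saturated chain carbon bound to an oxygen on an aromatic ring; the same difference, read one bond further out, is methoxy to benzyloxy. For the measured compounds named here, no measured step touches this position, so none of the three steps bears on it directly. With nothing to anchor a direction, the expectation for compound 4 is a step of no change at the digits printed from compound 2 to compound 4 (within the scatter) from compound 2, that is, no step beyond the scatter, with a wide range to allow for an unanchored change. The estimate for compound 4 in this assay is 7100 nM, between 2000 nM and 25000 nM.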

Compound 4, half-maximal inhibitory concentration: 2200 nM
Beside the measured number, compound 4's estimate is 3.2-fold (0.51 log units) above it; low and high end bracket the measured number.
By their numbers in this assay, from the lowest: compounds 4, 3 and 2 (each within the scatter of the next, the first and the last beyond it); then compound 1.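

In this assay, for the compounds shown here, the ether on the core proves responsive in its own right: with the amine and chain held constant, methoxy to benzyloxy gives a 3.2-fold lower number from compound 2 to compound 4 (0.51 log units; beyond the scatter), a step beyond the scatter at a position that none of the earlier steps touched. The amine end of the chain is therefore no longer the only part of the series where such a step is seen, and a phenyl on the saturated chain carbon bound to this oxygen is accommodated with a lower number rather than a higher one. Nothing available gives a reason for this step.

The compounds shown leave open whether the lower number belongs to the aromatic ring itself or simply to a larger group on this oxygen, a distinction that ethoxy and cyclohexylmethoxy groups at the same place could draw. Going by these compounds alone, with only one pair at this position, it also remains open whether benzyloxy in place of methoxy gives a step of similar size alongside other amines, such as the piperidin-1-yl group of compound 1.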